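The source may hold more compounds than are shown below. What is called first, only, known or untested is meant among the compounds shown, and "the series" means these compounds.

Measured compounds:
Compound 1 `COc1ccc(-c2cc(/C=C/C(=O)c3ccc(N)cc3)[nH]n2)cc1`: 780 nM
Compound 2 `COc1cc(-c2cc(/C=C/C(=O)c3ccc(N)cc3)[nH]n2)cc(OC)c1OC`: 1500 nM

Both compounds were tested in a functional assay on MCF7 cells (Homo sapiens) for inhibition, read by sulforhodamine B assay, with a stated time of 48 h; on this read-out lower numbers stand for stronger inhibition of growth and higher numbers for weaker inhibition of growth. Compound 2 gives 1500 nM, the higher of the two numbers. Its nearest neighbour is compound 1, which in this assay gives 780 nM; the gap between the two lies within the scatter of repeated measurements, so the numbers do not separate the two compounds.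

Compound 3 `COc1ccc(-c2cc(/C=C/C(=O)c3ccc(N)cc3)[nH]n2)cc1OC` has not yet been measured. It differs from compound 2 in one place: hydrogen in place of methoxy on an aromatic carbon. For the measured compounds named here, no pair of measured compounds shows exactly this change on its own. Compound 1 and compound 2 differ from each other in more than one place, and their two values show only that such differences on this ring left the numbers within the scatter. For compound 3, a step in this assay of no size beyond the scatter is therefore expected, in either direction, which is what a 1.4-fold lower number from compound 2 to compound 3 (0.13 log units; within the scatter) means. The estimate for compound 3 is 1100 nM, with a range from 500 nM to 2500 nM.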

Compound 3, concentration for 50% growth inhibition: 2280 nM
The estimate for compound 3 lay 2.1-fold (0.32 log units) below the measured number; low and high end bracket the measured number.
By their numbers in this assay, from the lowest: compounds 1, 2 and 3 (each within the scatter of the next, the first and the last beyond it).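

In this assay, hydrogen in place of methoxy on the aromatic carbon ortho to a methoxy group and meta to a large group gives a 1.5-fold higher number from compound 2 to compound 3 (0.18 log units; within the scatter), so this single change at this position does not separate the pair. The other one-place change on this ring, methoxy in place of hydrogen on an aromatic carbon, gives a 2.9-fold higher number from compound 1 to compound 3 (0.47 log units; beyond the scatter), a modest weakening of growth inhibition and the only step among these compounds that is beyond the scatter. No other kind of measurement is at hand to explain either step.

The compounds shown carry only methoxy or hydrogen at these ring positions, so it remains open whether a hydroxyl, a chlorine or an amine on the same aromatic carbon would move the number beyond the scatter. Also open, going by these compounds, is whether these steps would hold on a version of the shared core that carries a carboxylic acid in place of its amine.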